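From Methyl to Methoxy in a Weakly Cytotoxic Series

The source may hold more compounds than are shown below. What is called first, only, known or untested is meant among the compounds shown, and "the series" means these compounds.

In a functional assay on MCF7 cells (Homo sapiens) for cytotoxicity, read by MTT assay, with a stated time of 72 h (on this read-out lower numbers stand for stronger inhibition and higher numbers for weaker inhibition), compound 1 (`CNC(=O)c1cc(Oc2ccc(NC(=O)c3cc(-c4ccc(Cl)cc4)ncn3)cc2F)ccn1`) gives > 100000 nM, which is a limit of the assay and not a number. Compound 2 (`CNC(=O)c1cc(Oc2ccc(NC(=O)c3cc(-c4ccc(Br)cc4)ncn3)cc2F)ccn1`) gives > 100000 nM, again a limit. Compound 3 (`CNC(=O)c1cc(Oc2ccc(NC(=O)c3cc(-c4ccc(C)cc4)ncn3)cc2F)ccn1`), which bears methyl where the other two bear chloro and bromo, is the only one of the three with a number, at 19200 nM.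

Compound 4 (`CNC(=O)c1cc(Oc2ccc(NC(=O)c3cc(-c4ccc(OC)cc4)ncn3)cc2F)ccn1`) has methoxy in place of methyl on an aromatic carbon, para to a large group: methoxy in place of methyl on an aromatic carbon.

Within the data shown here, three measured steps concern this same carbon. Bromo in place of chloro gives a step that the two limits leave unreadable from compound 1 to compound 2. Methyl in place of chloro gives an at least 5.2-fold lower number from compound 1 to compound 3 (0.71 log units; beyond the scatter), and methyl in place of bromo gives an at least 5.2-fold lower number from compound 2 to compound 3 (0.71 log units; beyond the scatter). These show that the number can respond to a change at this carbon, but none of them involves methoxy, and the two limits hide their true size. Among the measured compounds shown here, with no measured step as a direct guide, compound 3 at 19200 nM is the natural anchor, and no step beyond the scatter is expected in this assay.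

The expected change is a 1.3-fold higher number from compound 3 to compound 4 (0.11 log units; within the scatter).

For compound 4 the estimated value is 25000 nM, with an expected range from 7000 nM to 100000 nM.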

Compound 4, half-maximal inhibitory concentration: 46200 nM
The estimate for compound 4 lay 1.8-fold (0.27 log units) below the measured number; the measured number falls inside the stated range.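

In this assay, among these compounds, methoxy at this carbon gives a 2.4-fold higher number from compound 3 to compound 4 (0.38 log units; beyond the scatter), the first step with a number at both ends and so the first whose true size can be read. Against the halogens, the same group gives an at least 2.1-fold lower number from compound 2 to compound 4 (0.33 log units; beyond the scatter) and an at least 2.1-fold lower number from compound 1 to compound 4 (0.33 log units; beyond the scatter), which shows that a second group besides methyl brings the number down from the bromo and chloro compounds. The position therefore separates methyl from methoxy as well as both from the halogens, with compound 3 still the strongest of the four, though the steps from the halogens are only minimum sizes: the limit of > 100000 nM in this assay, at which 2 of the 4 values shown sit.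

As far as these compounds go, the step between compound 1 and compound 2 cannot be read, and the true distance of either halogen compound from compound 3 and compound 4 remains unknown. From the compounds shown here alone, it also remains open whether an amine, a hydroxyl or a longer chain such as ethyl at this carbon would bring the number below that of compound 3, or whether the series stays this weak in this assay whatever group sits there.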